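The source may hold more compounds than are shown below. What is called first, only, known or untested is meant among the compounds shown, and "the series" means these compounds.

Three compounds share one core and differ only in the group bound to the carbonyl carbon. Compound 1 `Cc1ccccc1C(=O)n1c(-c2cn(-c3ccccc3)nc2-c2ccc(F)cc2)nc2ccccc21` carries a 2-methylphenyl there, and in an ADME assay on HEK-293T cells (Homo sapiens) for cytotoxicity, read by MTT assay, with a stated time of 24 h (on this read-out higher numbers stand for lower toxicity in this test and lower numbers for higher toxicity in this test), compound 1 gives 189000 nM. Compound 2 `O=C(c1ccncc1)n1c(-c2cn(-c3ccccc3)nc2-c2ccc(F)cc2)nc2ccccc21` carries a pyridin-4-yl, and in this assay compound 2 gives 151000 nM. Compound 3 `Cc1ccc(C(=O)n2c(-c3cn(-c4ccccc4)nc3-c3ccc(F)cc3)nc3ccccc32)cn1` carries a 6-methylpyridin-3-yl, and in this assay compound 3 gives 137000 nM. The three steps are small: a 1.3-fold lower number from compound 1 to compound 2 (0.10 log units; within the scatter), a 1.4-fold lower number from compound 1 to compound 3 (0.14 log units; within the scatter) and a 1.1-fold lower number from compound 2 to compound 3 (0.04 log units; within the scatter). Compound 3 thus gives the smallest of the three numbers, but its gaps to compound 2 and compound 1 are within the scatter, so the three cannot be told apart on these data.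

Compound 4 `O=C(c1cccnc1)n1c(-c2cn(-c3ccccc3)nc2-c2ccc(F)cc2)nc2ccccc21` is the next step from compound 3: hydrogen in place of methyl on an aromatic carbon. For the measured compounds named here, no measured step repeats this exact change; the steps that touch the same group, a 1.4-fold lower number from compound 1 to compound 3 (0.14 log units; within the scatter) and a 1.1-fold lower number from compound 2 to compound 3 (0.04 log units; within the scatter), swap whole ring groups and stay within the scatter. Removing a single methyl is a smaller change than any of those. Compound 4 is therefore expected to show a 1.1-fold higher number from compound 3 to compound 4 (0.04 log units; within the scatter), no step beyond the scatter, with an estimated value of 150000 nM and a likely range from 80000 nM to 280000 nM.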

Compound 4, half-maximal cytotoxic concentration: 216000 nM
Beside the measured number, compound 4's estimate is 1.4-fold (0.16 log units) below it; the measured number falls inside the stated range.
By their numbers in this assay, from the lowest: compounds 3, 2, 1 and 4 (each within the scatter of the next).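

Taking the methyl off the ring carbon next to the ring nitrogen gives a 1.6-fold higher number from compound 3 to compound 4 (0.20 log units; within the scatter) in this assay and so adds a direct reading for this single group: on these data, the methyl at this position cannot be told from a plain hydrogen. For the compounds shown here, the comparisons with the other two compounds read the same way, since pyridin-3-yl in place of pyridin-4-yl gives a 1.4-fold higher number from compound 2 to compound 4 (0.16 log units; within the scatter) and pyridin-3-yl in place of 2-methylphenyl gives a 1.1-fold higher number from compound 1 to compound 4 (0.06 log units; within the scatter) on the same carbonyl carbon, so neither a different ring nitrogen position nor a ring with no nitrogen separates these compounds in this test. Nothing measured alongside these numbers offers an explanation for them.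

As far as these compounds go, all four compounds carry a six-membered aromatic ring on the carbonyl carbon, so it remains open whether an amine, a carboxylic acid or a longer alkyl chain there would stay within the same narrow band of numbers. From the compounds shown here alone, it is also open whether a methoxy group or a chlorine atom on the ring carbon that held the methyl would give a step beyond the scatter.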